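Fluorophenyl in Place of Methoxyphenyl on the Amide Nitrogen

This account rests on a few compounds, and the source may have more. Where it says the series, first, only, none or still open, it means among the compounds named here.

Compound 1 `COc1ccc(NC(=O)/C=C/c2coc3cc(OC)ccc3c2=O)cc1` gives 718000 nM in an ADME assay on HepG2 2.2.15 cells (Homo sapiens) for cytotoxicity, read by MTT assay, with stated times of 48 h and 9 days; a lower number here means that less compound is tolerated, a higher number that more compound is tolerated. Compound 2 `COc1ccc2c(=O)c(/C=C/C(=O)Nc3ccccc3OC)coc2c1` gives 1050000 nM in this assay, and the step of a 1.5-fold higher number from compound 1 to compound 2 (0.17 log units; within the scatter) is within the scatter, so the two values show no real difference; compound 2 carries the higher of the two numbers without standing apart. Compound 3 `COc1ccc2c(=O)c(/C=C/C(=O)Nc3ccc(F)cc3)coc2c1` differs from compound 2 by 4-fluorophenyl in place of 2-methoxyphenyl on an amide-type nitrogen. Among the measured compounds shown here, the only measured step, from compound 1 to compound 2, moved a methoxy group around the ring and left the number essentially unchanged, which suggests the amide-bound aryl group has not so far mattered here; no measured step removes a methoxy group or introduces a fluorine. Compound 3 is therefore expected to show a 1.2-fold lower number from compound 2 to compound 3 (0.07 log units; within the scatter), a change not beyond the scatter. Compound 3 is estimated at 900000 nM in this assay, with a range from 450000 nM to 1800000 nM.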

Compound 3, half-maximal cytotoxic concentration: 743000 nM
Estimate against measurement, compound 3: 1.2-fold (0.08 log units) above, and the stated range covers the measured number.
By their numbers in this assay, from the lowest: compounds 1, 3 and 2 (each within the scatter of the next).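

In this assay, 4-fluorophenyl in place of 2-methoxyphenyl on the amide-type nitrogen gives a 1.4-fold lower number from compound 2 to compound 3 (0.15 log units; within the scatter), so a ring carrying fluorine instead of a methoxy group also leaves the number within the scatter. The closer comparison, fluoro in place of methoxy on an aromatic carbon, gives a 1.0-fold higher number from compound 1 to compound 3 (0.01 log units; within the scatter), which is likewise within the scatter. Across the three compounds, then, 4-methoxyphenyl, 2-methoxyphenyl and 4-fluorophenyl on this nitrogen cannot be told apart, and no supporting measurement is available to explain why.

As far as these compounds go, all three groups are substituted phenyl rings, so it remains open whether a ring carrying an amine or a carboxylic acid would also stay within the scatter. From the compounds shown here alone, it is equally open whether a simple alkyl chain in place of the ring on this nitrogen would do so.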